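Benzyloxy in place of phenoxy on the biaryl of compound 2

The compounds below may be only part of what the source reports. "The series", "measured", "known", "first", "only" and "open" are said of these compounds alone.

For the measured compounds named here, compound 2 `N#Cc1c(-c2ccc(Oc3ccccc3)cc2)ccn2c(CC(F)(F)F)cnc12` holds the higher of the two numbers so far: in a functional assay on CHO cells with metabotropic glutamate receptor 2 (Homo sapiens) as the target, read by GTPgammaS binding (a lower number here means a smaller maximal response, a higher number a larger maximal response), compound 2 gives 200%, while compound 1 `N#Cc1c(-c2ccc(N3CCCCC3)cc2)ccn2c(CC(F)(F)F)cnc12` gives 123%. Going by the values given here, the only measured step, a number 77 percentage points higher from compound 1 to compound 2 (beyond the scatter), exchanges a piperidin-1-yl for a phenoxy group and so does not speak directly to the change now at hand. Compound 3 `N#Cc1c(-c2ccc(OCc3ccccc3)cc2)ccn2c(CC(F)(F)F)cnc12` differs from compound 2 by benzyl in place of phenyl on an oxygen on an aromatic ring. Among the compounds with values here, with no measured step of this type, the expected shift of a number 25 percentage points lower from compound 2 to compound 3 (beyond the scatter) is uncertain and may lie within the scatter. Compound 3 is estimated at 175% in this assay, between 115% and 235%.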

Compound 3, largest response reached (Emax), in percent of the reference or control that the assay uses: 222%
Estimate against measurement, compound 3: 47 percentage points below; measured number inside the range.
By their numbers in this assay, from the lowest: compound 1; then compound 2; then compound 3.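

Moving from an oxygen-bound phenyl to an oxygen-bound benzyl does not cost maximal response in this assay, since the series shows a number 22 percentage points higher from compound 2 to compound 3 (beyond the scatter). With a number 99 percentage points higher from compound 1 to compound 3 (beyond the scatter) as well, compound 3 now stands highest of the three, and both oxygen-linked groups stand above the piperidin-1-yl group. No measurement shown here accounts for this rise.

As far as these compounds go, whether a longer chain on that oxygen, such as phenethyl, continues the trend remains open. So does the effect of a pyridyl ring in place of the phenyl of the benzyl.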